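Phenyl in Place of Isobutyl on a Carbamate Oxygen

The compounds below may be only part of what the source reports. "The series", "measured", "known", "first", "only" and "open" are said of these compounds alone.

Three compounds were measured in a functional assay on CCRF-CEM cells (Homo sapiens) for cytotoxicity, read by MTT assay, with a stated time of 72 h; on this read-out lower numbers stand for higher toxicity in this test and higher numbers for lower toxicity in this test:

compound 1, `CC(C)COC(=O)Nc1ccc([Se]C#N)cc1`: 68700 nM
compound 2, `N#C[Se]c1ccc(NC(=O)OCc2ccc([N+](=O)[O-])cc2)cc1`: 68800 nM
compound 3, `CCCCOC(=O)Nc1ccc([Se][Se]c2ccc(NC(=O)OCCCC)cc2)cc1`: 72300 nM

Compound 1 gives the lowest of the three numbers, but compound 2 and compound 3 both sit within the scatter of it, so the three values are indistinguishable in this assay. Among the measured compounds shown here, no pair among them differs in a single place, so no measured step is available.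

Compound 4, `N#C[Se]c1ccc(NC(=O)Oc2ccccc2)cc1`, differs from compound 1 by phenyl in place of isobutyl on an oxygen next to a carbonyl group. With every measured value sitting at the same level, nothing in the data points to a shift in either direction; the step of a 1.0-fold lower number from compound 1 to compound 4 (0.00 log units; within the scatter) is expected to be none beyond the scatter. Compound 4 is therefore expected to give 68000 nM, with a range from 34000 nM to 140000 nM.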

Compound 4, concentration lethal to 50% of the cells: 73200 nM
Beside the measured number, compound 4's estimate is 1.1-fold (0.03 log units) below it; the range from low to high includes it.
By their numbers in this assay, from the lowest: compounds 1, 2, 3 and 4 (each within the scatter of the next).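

Among the compounds shown here, the step at this position, a 1.1-fold higher number from compound 1 to compound 4 (0.03 log units; within the scatter) in this assay, is the first single-place comparison in the set, and it stays within the scatter. Phenyl in place of isobutyl on an oxygen next to a carbonyl group, which adds a six-membered aromatic ring, therefore leaves the number where it was. Nothing measured here bears on why this change makes no visible difference.

The compounds shown leave open whether any group at this place can move the number beyond the scatter. An amine, a carboxylic acid or a longer chain in place of isobutyl would test that.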